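Acetyl Capping in Two Related Ureas and Amides

The compounds below may be only part of what the source reports. "The series", "measured", "known", "first", "only" and "open" are said of these compounds alone.

Measured compounds:
Compound 1, `CC(=O)Nc1ncnc2c1ccn2-c1ccc(NC(=O)Nc2ccc(Cl)c(C(F)(F)F)c2)cc1`: > 10000 nM
Compound 2, `Nc1ncnc2c1ccn2-c1ccc(NC(=O)Nc2ccc(Cl)c(C(F)(F)F)c2)cc1`: > 10000 nM
Compound 3, `Nc1ncnc2c1ccn2-c1ccc(NC(=O)c2ccc(Cl)c(C(F)(F)F)c2)cc1`: 5600 nM

In an ADME assay on HS27 cells (Homo sapiens) for antiproliferative activity, read by MTT assay, with a stated time of 24 h (on this read-out higher numbers stand for weaker inhibition and lower numbers for stronger inhibition), compound 1 gives > 10000 nM, which is a limit of the assay rather than a number. Compound 2 likewise gives > 10000 nM, again a limit. Compound 3 is the only one of the three with a number in this assay, 5600 nM.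

Compound 2 and compound 1 differ by acetyl in place of hydrogen on a nitrogen on an aromatic ring. The step that the two limits leave unreadable from compound 2 to compound 1 cannot be read, because both values sit at the limit of > 10000 nM in this assay, at which 2 of the 3 values shown sit. For the measured compounds named here, how the core of compound 2 differs from the core of compound 3 is not broken down here; the two values show only that compound 3 gives a number where compound 2 gives a limit.

Compound 4, `CC(=O)Nc1ncnc2c1ccn2-c1ccc(NC(=O)c2ccc(Cl)c(C(F)(F)F)c2)cc1`, is not yet measured in this assay. It differs from compound 3 by acetyl in place of hydrogen on a nitrogen on an aromatic ring, the same change that takes compound 2 to compound 1, at a place described in the same words. Going by the values given here, since that earlier step is unreadable, the only guide is that an acetyl group added in this way did not move a value off the limit. Compound 4 is therefore expected to stay close to compound 3, with a 1.2-fold higher number from compound 3 to compound 4 (0.06 log units; within the scatter) estimated as a small step, and a fair chance that the assay again reports only a limit. The estimate for compound 4 is 6500 nM, between 2500 nM and 16000 nM.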

Compound 4, half-maximal inhibitory concentration: > 10000 nM
Compound 4: no number, only a limit; the forecaster's own chance of this, stated with the estimate: 35%; at least 1.5-fold (0.18 log units) between middle value and limit.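

In this assay compound 4 gives > 10000 nM, which is a limit of the assay and not a number. On the core of compound 3, the change from amino to acetamido therefore gives an at least 1.7-fold higher number from compound 3 to compound 4 (0.25 log units; that floor lies within the scatter), so the direction is upward, but only a floor on the size is known and that floor does not clear the usual scatter. The same change on the core of compound 2 cannot be read, and whether the change carries over from one core to the other with a similar size stays unshown, because compounds 1 and 2 both rest at the ceiling, and compound 2 does so without any acetyl group, so the acetyl group cannot be tied to the ceiling across both cores: the limit of > 10000 nM in this assay, at which 3 of the 4 values shown sit.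

The compounds shown leave open whether a different group on that nitrogen, such as a methyl group or a longer acyl chain like propanoyl, would give a number in this assay rather than a limit. They also leave open how far compound 4 actually lies past the limit, and how compound 1 and compound 2 would compare if each gave a number.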